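The source may report more compounds than this note shows. Statements on the series, on what has been measured and on what is new or still open speak of the compounds shown alone.

Measured in an ADME assay on THP-1 cells (Homo sapiens) for cytotoxicity; on this read-out lower numbers stand for stronger inhibition and higher numbers for weaker inhibition:
compound 1 `COc1ccccc1-c1nnc(-c2ccc(C(=O)N/N=C/c3cc(O)ccc3O)cc2)o1` gives 100000 nM;
compound 2 `COc1ccccc1-c1nnc(-c2ccc(C(=O)N/N=C/c3cccc([N+](=O)[O-])c3)cc2)o1` gives 119000 nM;
compound 3 `COc1ccccc1-c1nnc(-c2ccc(C(=O)N/N=C/c3ccccc3F)cc2)o1` gives 313000 nM.

Compound 3 has the highest number of the three; its nearest neighbour is compound 2 and its furthest compound 1, both steps beyond the scatter. The step to compound 4 `COc1ccccc1-c1nnc(-c2ccc(C(=O)N/N=C/c3cccc(O)c3O)cc2)o1` is 2,3-dihydroxyphenyl in place of 2-fluorophenyl on a carbon with a double bond to nitrogen. The measured step that bears on it is a 3.1-fold higher number from compound 1 to compound 3 (0.50 log units; beyond the scatter), which runs the opposite way: a dihydroxyphenyl replaced by the fluorophenyl raised the number modestly. The present change reverses that, though the entering group is the 2,3-dihydroxyphenyl rather than the 2,5-dihydroxyphenyl, for which no measured comparison exists. A modest step downward in this assay is therefore expected, a 2.8-fold lower number from compound 3 to compound 4 (0.45 log units; beyond the scatter). Compound 4 is estimated at 110000 nM in this assay, within 40000 nM to 300000 nM.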

Compound 4, half-maximal inhibitory concentration: 102000 nM
Beside the measured number, compound 4's estimate is 1.1-fold (0.03 log units) above it; the measured number falls inside the stated range.
By their numbers in this assay, from the lowest: compounds 1, 4 and 2 (each within the scatter of the next); then compound 3.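

In this assay, a second dihydroxyphenyl group separates from the 2-fluorophenyl on the carbon with a double bond to nitrogen, with a 3.1-fold lower number from compound 3 to compound 4 (0.49 log units; beyond the scatter), so compound 3 stands apart from both dihydroxyphenyl compounds. The two dihydroxyphenyl groups cannot be told apart, with a 1.0-fold higher number from compound 1 to compound 4 (0.01 log units; within the scatter), nor can the 3-nitrophenyl and 2,3-dihydroxyphenyl groups, with a 1.2-fold lower number from compound 2 to compound 4 (0.07 log units; within the scatter). No available evidence accounts for these steps.

Still open, on these data alone, is how a phenyl bearing an amine or a carboxylic acid would read in this place in this assay.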